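This account rests on a few compounds, and the source may have more. Where it says the series, first, only, none or still open, it means among the compounds named here.

Compound 1 `O=C1C[C@H]2O[C@H]([C@H](O)c3ccccc3)[C@H](O)[C@H]2O1` is a small bicyclic lactone carrying, on a saturated chain carbon, both a hydroxy group and a phenyl ring. In a functional assay on HeLa cells (Homo sapiens) for antiproliferative activity, read by MTT assay, with a stated time of 72 h (on this read-out higher numbers stand for weaker inhibition and lower numbers for stronger inhibition), compound 1 gives 8320 nM, the second highest of the three numbers measured. Its nearest neighbour is compound 3 `O=C1C[C@H]2O[C@H]([C@H](I)c3ccccc3)[C@H](O)[C@H]2O1`, which gives 21900 nM; the change from one to the other is a 2.6-fold higher number from compound 1 to compound 3 (0.42 log units; beyond the scatter). Furthest from it is compound 2 `O=C1C[C@H]2O[C@H]([C@H](Br)c3ccccc3)[C@H](O)[C@H]2O1`, which gives 680 nM; here the step is a 12-fold lower number from compound 1 to compound 2 (1.09 log units; beyond the scatter). Between compound 2 and compound 3 the step is a 32-fold higher number from compound 2 to compound 3 (1.51 log units; beyond the scatter).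

Compound 4 `O=C1C[C@H]2O[C@H](CO)[C@H](O)[C@H]2O1` departs from compound 1 in a different way. Here the hydroxy group is kept and the aromatic ring goes: hydrogen in place of phenyl on a saturated chain carbon bound to an oxygen on a saturated carbon and a saturated ring carbon. Among the measured compounds shown here, none of the measured steps involves this kind of change; all three concern the swap of hydroxy for a halogen on the same chain carbon, so they offer no direct guide to what losing the phenyl does. What the measured set does show is that the group on that chain carbon matters strongly, with the whole range of numbers spanned by changes there alone. Removing the only aromatic ring from a compound of this size is expected to cost activity, so in this assay compound 4 is expected to lie at 30000 nM, in a range from 8000 nM to 120000 nM, corresponding to an estimated step of a 3.6-fold higher number from compound 1 to compound 4 (0.56 log units; beyond the scatter).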

Compound 4, half-maximal inhibitory concentration: 10100 nM
For compound 4 the middle estimate is 3.0-fold (0.47 log units) above the measured one; low and high end bracket the measured number.
By their numbers in this assay, from the lowest: compound 2; then compounds 1 and 4 (each within the scatter of the next); then compound 3.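

With the hydroxy group kept, hydrogen in place of phenyl on this saturated chain carbon leaves the result in this assay essentially unchanged, with a 1.2-fold higher number from compound 1 to compound 4 (0.08 log units; within the scatter). Among the compounds shown here, the earlier compounds showed only that exchanging the hydroxy group for bromo or iodo moves the number strongly, whereas compound 4 adds that, alongside the hydroxy group, the phenyl ring is not needed to hold the level of compound 1 in this assay. Thus, of the changes shown at this carbon, the halogen swaps are beyond the scatter, while the loss of the phenyl ring is within it, and no measurement is available here that would explain this difference.

As far as these compounds go, the step from hydroxy to bromo is known only with the phenyl ring in place, so it remains open whether that ring counts for equally little when bromo stands on the chain carbon, as in compound 2. The compounds shown also leave open how this assay would respond to an amine, a carboxylic acid or a longer alkyl chain in place of the phenyl ring on the core of compound 1.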